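Chain length and the hydroxamic acid on a shared core

A few compounds are considered here, and "the series" means these few. Any claim that something is new, unique, unknown or untested is made for them only; others in the source may bear on it.

Compound 1 `Nc1nc2cc(-c3nn(CCCCCC(=O)NO)c4ncnc(N)c34)ccc2o1`: 1990 nM
Compound 2 `Nc1nc2cc(-c3nn(CCCCCCCCCC(=O)NO)c4ncnc(N)c34)ccc2o1`: 28600 nM
Compound 3 `Nc1nc2cc(-c3nn(CCCC(=O)NO)c4ncnc(N)c34)ccc2o1`: only a limit, > 50000 nM

Three compounds share one core and differ only in the chain carrying the hydroxycarbamoyl group. In a functional assay on HepG2 cells (Homo sapiens) for inhibition, read by MTT assay, with a stated time of 72 h (a lower number here means a stronger inhibitor, a higher number a weaker inhibitor), compound 1 gives 1990 nM. Compound 2 gives 28600 nM in this assay. For compound 3 this assay reports only a limit, > 50000 nM, so compound 3 stands at the floor of the measurable range (the limit of > 50000 nM in this assay, at which 1 of the 3 values shown sits). The move from compound 3 to the unmeasured compound 4 `Nc1nc2cc(-c3nn(CCCCCCCCC(=O)NO)c4ncnc(N)c34)ccc2o1` is 5-(hydroxycarbamoyl)pentyl in place of hydroxycarbamoyl on a saturated chain carbon, three bonds along the chain from an aromatic nitrogen. The same kind of lengthening has been seen twice: an at least 25-fold higher number from compound 1 to compound 3 (1.40 log units; beyond the scatter), and a 14-fold higher number from compound 1 to compound 2 (1.16 log units; beyond the scatter), while an at least 1.7-fold higher number from compound 2 to compound 3 (0.24 log units; that floor lies within the scatter). Compound 4 sits between compound 1 and compound 2 in chain length, closer to compound 2, so a large drop in the number from compound 3 is expected, landing near the value of compound 2: the expected step is an at least 3.3-fold lower number from compound 3 to compound 4 (0.52 log units; beyond the scatter). Compound 4 is expected to give 15000 nM, within 5000 nM to 45000 nM.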

Compound 4, half-maximal inhibitory concentration: 2610 nM
Estimate against measurement, compound 4: 5.7-fold (0.76 log units) above; measured number below the stated range.
By their numbers in this assay, from the lowest: compounds 1 and 4 (each within the scatter of the next); then compound 2. At a limit, above all of these: compound 3.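

Trimming the chain end of the longest chain, hydroxycarbamoyl in place of (hydroxycarbamoyl)methyl, gives an 11-fold lower number from compound 2 to compound 4 (1.04 log units; beyond the scatter) and so shows that the loss at the long end of the series sets in abruptly. Compound 4 also matches compound 1 despite its longer chain, with a 1.3-fold higher number from compound 1 to compound 4 (0.12 log units; within the scatter) for 3-(hydroxycarbamoyl)propyl in place of hydroxycarbamoyl, so among these compounds a range of chain lengths is tolerated, and compound 2 and compound 3 fall outside it. Lengthening the short chain gives an at least 19-fold lower number from compound 3 to compound 4 (1.28 log units; beyond the scatter) in this assay, but its starting point is a limit, not a number: the limit of > 50000 nM in this assay, at which 1 of the 4 values shown sits.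

From the compounds shown here alone, whether a carboxylic acid or a primary amide at the chain end would keep any of this inhibition stays open. So does the effect of a chain of any other length on the shared core.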